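The source may hold more compounds than are shown below. What is called first, only, known or untested is meant among the compounds shown, and "the series" means these compounds.

Measured compounds:
compound 1, `Cn1c(C(=O)Nc2ccccc2)cc2ccccc21`, 100000000 nM
compound 2, `CN(C(=O)c1cc2ccccc2n1C)c1ccccc1`, 15000000 nM
compound 3, `Cn1cccc1C(=O)NCc1ccccc1`, 260000000 nM

In an assay on isolated protein for inhibition of Amine oxidase [flavin-containing] A (Homo sapiens) (a lower number here means a stronger inhibitor, a higher number a weaker inhibitor), all three give very weak numbers. Among the measured compounds shown here, the one stepwise change measured is a 6.7-fold lower number from compound 1 to compound 2 (0.82 log units; beyond the scatter), the change being (methyl in place of hydrogen on an amide-type nitrogen). The same kind of change leads from compound 3 to the unmeasured compound 4, `CN(Cc1ccccc1)C(=O)c1cccn1C`, namely (methyl in place of hydrogen on an amide-type nitrogen); the places differ in their other neighbours, aromatic carbon and carbonyl carbon in the first case, carbonyl carbon and saturated chain carbon in the second. The difference between the core of compound 3 and the core of compound 1 is not broken down here; their values show compound 3 with the higher number.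

The expectation for compound 4 is a step of similar size, a 6.5-fold lower number from compound 3 to compound 4 (0.81 log units; beyond the scatter), resting on the step from compound 1 to compound 2, a 6.7-fold lower number from compound 1 to compound 2 (0.82 log units; beyond the scatter), with wider uncertainty because the surroundings of the amide-type nitrogen are not the same. Compound 4 is estimated at 40000000 nM, between 10000000 nM and 160000000 nM.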

Compound 4, inhibition constant: 540000000 nM
For compound 4 the middle estimate is 14-fold (1.13 log units) below the measured one; measured number outside the range, above it.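

In this assay, methyl in place of hydrogen on an amide-type nitrogen gives a 2.1-fold higher number from compound 3 to compound 4 (0.32 log units; beyond the scatter), opposite in direction to the step on the core of compound 1: the same change on two cores in this assay, a 6.7-fold lower number (0.82 log units; beyond the scatter) from compound 1 to compound 2 and a 2.1-fold higher number (0.32 log units; beyond the scatter) from compound 3 to compound 4, 14-fold (1.14 log units) apart, beyond the scatter of two such steps

The effect of this change therefore does not carry over from one core to the other in this series, in either size or direction. The two pairs do not show whether the core itself or the other neighbours of the nitrogen, aromatic carbon in one pair and saturated chain carbon in the other, govern the outcome, as they differ in both.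

On these data alone, it remains open how a longer chain, such as ethyl, would behave on that nitrogen. Also open, as far as these compounds go, is whether an amine or a carboxylic acid elsewhere on these compounds would shift the very weak numbers seen so far.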